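One Ring Swap, Measured Once, Predicted Once

A few compounds are considered here, and "the series" means these few. Any claim that something is new, unique, unknown or untested is made for them only; others in the source may bear on it.

Compound 1 `COC(=O)N(C)C(C)C#CCN1CCCC1` and compound 3 `CCOC(=O)N(C)CC#CCN1CCCC1` are built from the same atoms joined differently; how their two cores differ is not broken down here. Each carries a pyrrolidin-1-yl group on a saturated chain carbon bound to a triple-bonded carbon. Compound 2 `COC(=O)N(C)C(C)C#CCn1ccnc1` is compound 1 with that group exchanged: 1H-imidazol-1-yl in place of pyrrolidin-1-yl on a saturated chain carbon bound to a triple-bonded carbon. Compound 4 `CCOC(=O)N(C)CC#CCn1ccnc1` is the matching partner of compound 3 and has not yet been tested: 1H-imidazol-1-yl in place of pyrrolidin-1-yl on a saturated chain carbon bound to a triple-bonded carbon.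

The three measured compounds were run in a functional assay on the whole organism for antagonist activity, with Mus musculus as the target; a higher number here means that more compound is needed for the effect, a lower number that less compound is needed. In this assay compound 1 gives > 100 mg/kg, which is a limit of the assay rather than a number. Compound 2 gives > 100 mg/kg, again only a limit. Compound 3 gives > 100 mg/kg, also a limit. Because all three values sit at the limit of > 100 mg/kg in this assay, at which 3 of the 3 values shown sit, the pair gives only a step that the two limits leave unreadable from compound 1 to compound 2.

The change from compound 3 to compound 4 is the same change as from compound 1 to compound 2, made at the same place. For compound 4 the expected step is a step that the limit leaves unreadable from compound 3 to compound 4, too small to move the value out of the limit region. That expectation rests on compound 1, compound 2 and compound 3 all sitting at the limit of > 100 mg/kg in this assay, at which 3 of the 3 values shown sit. Compound 4 is therefore estimated at about 200 mg/kg, expected between 100 mg/kg and 500 mg/kg, and most likely reported once more only as a limit.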

Compound 4, dose for half-maximal effect: 97 mg/kg
Compound 4: middle estimate off by 2.1-fold (0.31 log units), on the high side; measured number outside the range, below it.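

In this assay the exchange of pyrrolidin-1-yl for 1H-imidazol-1-yl on the core of compound 3 gives an at least 1.0-fold lower number from compound 3 to compound 4 (0.01 log units; that floor lies within the scatter), so this change on this core yields a measured value, yet the floor of that step does not separate the two compounds. Compound 3 gives > 100 mg/kg, which is a limit of the assay and not a number, so the real size of the step may exceed its floor, but nothing shown fixes that size. The same exchange on the core of compound 1 cannot be read, and the carry-over from one core to the other is neither confirmed nor refuted, because both compounds of that pair sit at the edge of what the assay reports: the limit of > 100 mg/kg in this assay, at which 3 of the 4 values shown sit.

From the compounds shown here alone, it remains open whether the exchange would have a readable size on a core whose pyrrolidin-1-yl compound gives an actual number rather than a limit. Also open, going by these compounds, is how a piperidin-1-yl ring or a dimethylamino group would read on a saturated chain carbon bound to a triple-bonded carbon, on either core.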